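A few compounds are considered here, and "the series" means these few. Any claim that something is new, unique, unknown or untested is made for them only; others in the source may bear on it.

Measured compounds in an assay on cells for agonist activity at ecdysone receptor (Bombyx mori), read by a luciferase reporter, with a stated time of 24 h; on this read-out lower numbers stand for an effect already at smaller amounts and higher numbers for an effect only at larger amounts of compound:
compound 1 `CC(C)(C)N(NC(=O)c1ccccc1)C(=O)c1ccccc1Cl` — 75.9 nM
compound 2 `CC(C)(C)N(NC(=O)c1ccccc1Br)C(=O)c1ccccc1Cl` — 316 nM
compound 3 `CC(C)(C)N(NC(=O)c1ccc(I)cc1)C(=O)c1ccccc1Cl` — 7.59 nM

Compound 3 stands lowest of the three numbers; its nearest neighbour is compound 1 a 10-fold lower number from compound 1 to compound 3 (1.00 log units; beyond the scatter) and the furthest compound 2 a 42-fold lower number from compound 2 to compound 3 (1.62 log units; beyond the scatter). Compound 4 `CCc1ccc(C(=O)NN(C(=O)c2ccccc2Cl)C(C)(C)C)cc1` differs from compound 3 by ethyl in place of iodo on an aromatic carbon. The step that bears on it is the introduction of that iodo, a 10-fold lower number from compound 1 to compound 3 (1.00 log units; beyond the scatter); the other measured step, a 4.2-fold higher number from compound 1 to compound 2 (0.62 log units; beyond the scatter), concerns a different ring and a different substituent. Among the measured compounds shown here, no measured step replaces iodo by ethyl, so the gain seen in compound 3 cannot be assumed to carry over in full, yet a para substituent remains. Compound 4 is therefore expected to sit between compound 1 and compound 3, with a step of a 1.6-fold higher number from compound 3 to compound 4 (0.20 log units; within the scatter) estimated; the estimate for compound 4 is 12 nM (4 nM to 40 nM).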

Compound 4, half-maximal effective concentration: 5.75 nM
Estimate against measurement, compound 4: 2.1-fold (0.32 log units) above; the measured number falls inside the stated range.
By their numbers in this assay, from the lowest: compounds 4 and 3 (each within the scatter of the next); then compound 1; then compound 2.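

In this assay, the position para to a large group tolerates an exchange of iodo for ethyl with no readable change (a 1.3-fold lower number from compound 3 to compound 4 (0.12 log units; within the scatter)). The low numbers at this position are thus not confined to iodo: ethyl in place of hydrogen also gives a step beyond the scatter (a 13-fold lower number from compound 1 to compound 4 (1.12 log units; beyond the scatter)), and 4-ethylphenyl in place of 2-bromophenyl gives a large one (a 55-fold lower number from compound 2 to compound 4 (1.74 log units; beyond the scatter)). Nothing available explains why iodo and ethyl match here.

As far as these compounds go, whether a longer chain, such as butyl, or an amine at this position would keep these low numbers remains open.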